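The compounds below may be only part of what the source reports. "The series", "measured", "known", "first", "only" and "open" are said of these compounds alone.

For the measured compounds named here, in a functional assay on CCRF-CEM cells (Homo sapiens) for inhibition, read by MTT assay, with a stated time of 72 h (a lower number here means a stronger inhibitor, a higher number a weaker inhibitor), compound 2 `COc1cc(NC(C)CCCNC(=O)Nc2ccc(C(F)(F)F)cc2)c2ncccc2c1` gives 14000 nM, the lower of the two numbers so far, while compound 1 `COc1cc(NC(C)CCCNC(=O)NNC(=O)Nc2ccc(Cl)cc2)c2ncccc2c1` gives 108000 nM. Compound 3 `COc1cc(NC(C)CCCNC(=O)Nc2ccc(Cl)cc2)c2ncccc2c1` has chloro in place of trifluoromethyl on an aromatic carbon, para to a large group: chloro in place of trifluoromethyl on an aromatic carbon. Going by the values given here, the only measured step, a 7.7-fold lower number from compound 1 to compound 2 (0.89 log units; beyond the scatter), replaces a whole terminal group and does not isolate this exchange, so it bears on it only loosely. On these data alone, no step beyond the scatter is therefore expected in this assay, and the direction stays open. The expected shift is a 1.3-fold higher number from compound 2 to compound 3 (0.11 log units; within the scatter). For compound 3 the estimated value is 18000 nM, with an expected range of 7000 nM to 45000 nM.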

Compound 3, half-maximal inhibitory concentration: 24000 nM
For compound 3 the middle estimate is 1.3-fold (0.12 log units) below the measured one; the measured number falls inside the stated range.
By their numbers in this assay, from the lowest: compounds 2 and 3 (each within the scatter of the next); then compound 1.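

In this assay, the exchange of trifluoromethyl for chloro on the aromatic carbon para to a large group gives a 1.7-fold higher number from compound 2 to compound 3 (0.23 log units; within the scatter) and so does not separate the two groups. With chloro now held constant, a 4.5-fold lower number from compound 1 to compound 3 (0.65 log units; beyond the scatter) shows that the ((4-chlorophenyl)carbamoyl)amino arrangement carries a penalty against 4-chlorophenyl on the amide-type nitrogen that does not depend on the trifluoromethyl group of compound 2. No supporting data bear on the reason for either step. Still open, on these data alone, is whether a methoxy group, an amine or a carboxylic acid on that aromatic carbon would shift the number beyond the scatter. As far as these compounds go, a longer chain in the linker also remains untested in these compounds.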